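Amino in place of methoxy on compound 3

The source may hold more compounds than are shown below. What is called first, only, known or untested is meant among the compounds shown, and "the series" means these compounds.

In an ADME assay on CHO cells (Cricetulus griseus) for cytotoxicity, read by MTT assay, with a stated time of 24 h (a lower number here means that less compound is tolerated, a higher number that more compound is tolerated), compound 1 (`Cc1ccc(-c2c([N+](=O)[O-])nc3n2CC(C)O3)cc1`) gives > 250000 nM, which is a limit and not a number. Compound 2 (`CC1Cn2c(nc([N+](=O)[O-])c2-c2ccc(C=O)cc2)O1`) gives 255000 nM. Compound 3 (`COc1cccc(C#Cc2c([N+](=O)[O-])nc3n2CC(C)O3)c1`) gives 12900 nM, the lower of the two actual numbers and beyond the scatter from the other.

Compound 4 (`CC1Cn2c(nc([N+](=O)[O-])c2C#Cc2cccc(N)c2)O1`) differs from compound 3 by amino in place of methoxy on an aromatic carbon, meta to a large group: amino in place of methoxy on an aromatic carbon.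

Within the data shown here, the one measured step is a step that the limit leaves unreadable from compound 1 to compound 2, with formyl in place of methyl on an aromatic carbon. It replaces a different group and offers no size to carry over because of the limit of > 250000 nM in this assay, at which 1 of the 3 values shown sits. Among the measured compounds shown here, no measured step covers methoxy or amino, so the expectation stays anchored on compound 3 at 12900 nM in this assay, with no direction favoured. The estimated change is a 1.2-fold higher number from compound 3 to compound 4 (0.07 log units; within the scatter), and no step beyond the scatter is expected. For compound 4 the estimated value is 15000 nM, with an expected range from 5000 nM to 50000 nM.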

Compound 4, half-maximal cytotoxic concentration: 18100 nM
The estimate for compound 4 lay 1.2-fold (0.08 log units) below the measured number; the range from low to high includes it.
By their numbers in this assay, from the lowest: compounds 3 and 4 (each within the scatter of the next); then compound 2.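

In this assay, among these compounds, amino in place of methoxy on an aromatic carbon, meta to a large group, gives a 1.4-fold higher number from compound 3 to compound 4 (0.15 log units; within the scatter), the first step with a readable size. At this position, then, a group with a hydrogen-bond donor can stand in place of one without, with one heavy atom fewer, and the number stays within the scatter. Nothing measured here bears on why this exchange leaves the number within the scatter.

From the compounds shown here alone, whether this position would read the same with a carboxylic acid, a nitrile or a longer chain such as ethoxy remains open. Also open is whether amino in place of methoxy would give a similar step on the core of compound 1, where no such pair is shown.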